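What Happens When the Heptyl Group Leaves?

This account rests on a few compounds, and the source may have more. Where it says the series, first, only, none or still open, it means among the compounds named here.

Only two results are available so far for this small series of compounds. In a functional assay on PC-3 cells (Homo sapiens) for inhibition, read by MTT assay, with stated times of 18 h and 4 h (a lower number here means a stronger inhibitor, a higher number a weaker inhibitor), compound 1 `CCCOP(=O)(O)OCCSC(=S)N1CCCCC1` gives > 100000 nM as its result, which is a limit of the assay and not a number. For the measured compounds named here, compound 2 `CCCCCCCCCCOP(=O)(O)OCCSC(=S)N1CCCC1` gives 56100 nM and so holds the only true number so far, which means it cannot yet be ranked precisely against anything else. Compound 3 `CCCOP(=O)(O)OCCSC(=S)N1CCCC1` has not been measured. It differs from compound 2 at one place hydrogen in place of heptyl on a saturated chain carbon, three bonds along the chain from an oxygen on an unsaturated carbon with hydrogen in place of heptyl on a saturated chain carbon, three bonds along the chain from an oxygen on an unsaturated carbon. Going by the values given here, no measured pair shows what such a change does, so any forecast here is rough. Compound 2 at 56100 nM is already a weak inhibitor, and that leaves room to expect only a modest change. The expected step of a 2.0-fold higher number from compound 2 to compound 3 (0.29 log units; within the scatter) points toward weaker inhibition in this assay and may reach a limit rather than a number. For compound 3 the estimate is 110000 nM with an expected range from 50000 nM to 250000 nM if a number is reported at all.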

Compound 3, half-maximal inhibitory concentration: > 100000 nM
Compound 3 ended at the assay's limit; the forecaster's own chance of this, stated with the estimate: 65%; the middle value is on the limit's open side.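

For the compounds shown here, this is the first measured pair that differs in one place only: heptyl leaves and hydrogen enters on a saturated chain carbon, three bonds along the chain from an oxygen on an unsaturated carbon. In this assay, that exchange gives an at least 1.7-fold higher number from compound 2 to compound 3 (0.25 log units; that floor lies within the scatter). This figure is only a floor, so the pair shows no change beyond the scatter, yet the true step could be much larger, and the data cannot settle its size because the read-out stops at a limit: the limit of > 100000 nM in this assay, at which 2 of the 3 values shown sit.

As far as these compounds go, the step between the pyrrolidin-1-yl and piperidin-1-yl compounds cannot be read, as both values are limits, so the effect of that ring change remains unknown. Going by these compounds alone, also open is how the result depends on chain length: a butyl or hexyl chain at this place, or a chain longer than the one in compound 2, would be needed to show whether activity changes gradually, changes abruptly or keeps changing beyond compound 2.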